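The source may hold more compounds than are shown below. What is called first, only, known or untested is meant among the compounds shown, and "the series" means these compounds.

Measured so far in an assay for inhibition of Fatty-acid amide hydrolase 1 (Rattus norvegicus), using a Dixon plot; on this read-out higher numbers stand for weaker inhibition and lower numbers for stronger inhibition: compound 1 `COC(=O)c1ccc(-c2cnc(C(=O)CCCCCCc3ccccc3)o2)nc1` at 3.1 nM, and compound 2 `O=C(CCCCCCc1ccccc1)c1ncc(-c2ccc(CCl)cn2)o1` at 22.4 nM.

Compound 2 stands at the higher of the two numbers; the step of a 7.2-fold higher number from compound 1 to compound 2 (0.86 log units; beyond the scatter) separates it from compound 1. Compound 3 `CSC(=O)CCCCc1cnc(C(=O)CCCCCCc2ccccc2)o1` differs from compound 2 by a group of 8 heavy atoms (6 carbon, 1 oxygen, 1 sulfur; no ring) in place of a group of 8 heavy atoms (6 carbon, 1 nitrogen, 1 chlorine; one six-membered aromatic ring with 1 hetero atom), on an aromatic carbon. No measured step concerns this place: the one step shown, a 7.2-fold higher number from compound 1 to compound 2 (0.86 log units; beyond the scatter), alters a substituent on the ring that now leaves, not the ring itself, so it gives little guidance. With the ring replaced by an open chain, compound 3 is expected to show weaker inhibition, a change of a 2.7-fold higher number from compound 2 to compound 3 (0.43 log units; beyond the scatter). The estimate for compound 3 is 60 nM, within 15 nM to 250 nM.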

Compound 3, inhibition constant: 1.8 nM
For compound 3 the middle estimate is 33-fold (1.52 log units) above the measured one; the whole stated range lies above it.
By their numbers in this assay, from the lowest: compounds 3 and 1 (each within the scatter of the next); then compound 2.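

In this assay, an open chain in place of the six-membered aromatic ring gives a 12-fold lower number from compound 2 to compound 3 (1.09 log units; beyond the scatter), so a ring is not required at this place next to the ring oxygen. Compound 3 at 1.8 nM lies within the scatter of compound 1 at 3.1 nM, so the open chain reaches the same range as the ring bearing methoxycarbonyl. Nothing available explains why this exchange changes the number. As far as these compounds go, what remains open is what a carboxylic acid or a primary amide at the end of this chain would give, and whether a shorter chain would keep the value.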